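Amide-linked iminosugars: bromo for methoxy on the aryl tail

The source may report more compounds than this note shows. Statements on the series, on what has been measured and on what is new or still open speak of the compounds shown alone.

Measured compounds:
- compound 1 `COc1ccc(OC)c(/C=C/C(=O)NC[C@H]2NC[C@H](O)[C@@H](O)[C@H]2O)c1` — 99%
- compound 2 `O=C(CCCCC1CCCCC1)NC[C@H]1NC[C@H](O)[C@@H](O)[C@H]1O` — 99%
- compound 3 `CC(C)=CCCC(C)CC(=O)NC[C@H]1NC[C@H](O)[C@@H](O)[C@H]1O` — 99%

In an assay on isolated protein for inhibition of alpha-galactosidase A (Homo sapiens), read by fluorescence, tested at 100 uM (on this read-out higher numbers stand for more inhibition at the one concentration tested (going by the name of the read-out) and lower numbers for less inhibition), compound 1 gives 99%. In this assay compound 2 gives 99% and compound 3 gives 99%. Compound 1 is level with both at the digits shown; the nearest is compound 2 and the furthest is compound 3, and neither difference reaches beyond the scatter. The three tails on the shared core differ widely, one aromatic and two aliphatic, yet all three compounds sit at the same high level, so within this set the read-out at the single concentration does not separate them.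

Compound 4 `COc1ccc(Br)cc1/C=C/C(=O)NC[C@H]1NC[C@H](O)[C@@H](O)[C@H]1O` has not been measured. It differs from compound 1 by bromo in place of methoxy on an aromatic carbon. Among the compounds with values here, no step between measured compounds is available for this exchange, so the expectation rests on the three measured values lying together near the top of the scale. The expected step of a number 2 percentage points lower from compound 1 to compound 4 (within the scatter) is none beyond the scatter. For compound 4 the estimated value is 97%, with a range from 88% to 100%.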

Compound 4, a percentage reported as inhibition, at one concentration (the size of the read-out at that concentration, not a potency): 99%
Beside the measured number, compound 4's estimate is 2 percentage points below it; the measured number falls inside the stated range.
By their numbers in this assay, from the lowest: compounds 1, 2, 3 and 4 (each within the scatter of the next).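

In this assay, bromo in place of methoxy on an aromatic carbon, meta to a large group and para to a methoxy group, gives no change at the digits printed from compound 1 to compound 4 (within the scatter). The earlier compounds shown here differ across whole tails, whereas this pair isolates one place and shows that the read-out at the one concentration tested does not depend on a methoxy group there. No available evidence explains this result.

With all four compounds near the top of the scale, a single-concentration read-out leaves open whether the exchange alters potency at all, a question only lower concentrations could address. Also open, going by these compounds, is whether an amine or a carboxylic acid at this aromatic carbon would keep the read-out at this level.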